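This account rests on a few compounds, and the source may have more. Where it says the series, first, only, none or still open, it means among the compounds named here.

Measured compounds:
- Compound 1 `COc1ccc(-c2cc(/C=C/C(=O)c3ccc(N)cc3)[nH]n2)cc1`: 77%
- Compound 2 `COc1cc(-c2cc(/C=C/C(=O)c3ccc(F)c(F)c3)[nH]n2)cc(OC)c1OC`: 95%

In a functional assay on KM12 cells (Homo sapiens) for cytotoxicity, read by sulforhodamine B assay, with a stated time of 48 h, tested at 1 uM (on this read-out higher numbers stand for a weaker effect at the one concentration tested and lower numbers for a stronger effect), compound 1 gives 77%, the lowest of the two numbers shown. Compound 2 gives 95% in this assay, a number higher than that of compound 1 by a margin beyond the usual scatter, so compound 1 shows the stronger effect at the one concentration tested.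

Compound 3 `COc1ccc(-c2cc(/C=C/C(=O)c3ccc(N)cc3)[nH]n2)cc1OC` has not yet been measured. It differs from compound 1 by methoxy in place of hydrogen on an aromatic carbon. For the measured compounds named here, no pair of measured compounds that differ in a single place is available, so no comparable step can be read off. In this assay compound 3 is expected to stay close to compound 1, and the step from compound 1 to compound 3 is expected to be small, at the edge of the scatter, in the direction of a weaker effect, a number 6 percentage points higher from compound 1 to compound 3 (within the scatter). Compound 3 is therefore estimated at 83%, with a range from 66% to 98%.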

Compound 3, a percentage reported as activity, at one concentration (the size of the read-out at that concentration, not a potency): 88%
Estimate against measurement, compound 3: 5 percentage points below; measured number inside the range.
By their numbers in this assay, from the lowest: compound 1; then compounds 3 and 2 (each within the scatter of the next).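

In this assay, the step from methoxy in place of hydrogen on an aromatic carbon, ortho to a methoxy group and meta to a large group, is a number 11 percentage points higher from compound 1 to compound 3 (beyond the scatter). This is the first change in a single place among the compounds shown, and it shows that this position is not indifferent to substitution: adding the methoxy group weakens the effect at the one concentration tested, though only modestly. No measurement shown accounts for this step.

The compounds shown leave open whether a hydroxy group, a chlorine or an ethoxy group on this same aromatic carbon would give a similar step. They also leave open whether the methoxy group already present in compound 1 is needed for the effect seen there.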